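Replacing 2-bromophenyl with 3-methoxyphenyl on a shared core

The compounds below may be only part of what the source reports. "The series", "measured", "known", "first", "only" and "open" are said of these compounds alone.

Compounds measured so far in a functional assay on MCF7 cells (Homo sapiens) for cytotoxicity, read by MTT assay, with a stated time of 96 h; a lower number here means a stronger inhibitor, a higher number a weaker inhibitor
Compound 1 `COc1cc(C(=O)c2cn(-c3cccc(Cl)c3)cc2-c2ccccc2)cc(OC)c1OC` gives 150 nM
Compound 2 `COc1cccc(-n2cc(C(=O)c3cc(OC)c(OC)c(OC)c3)c(-c3ccccc3)c2)c1` gives 500 nM
Compound 3 `COc1cc(C(=O)c2cn(-c3ccccc3)cc2-c2ccccc2Br)cc(OC)c1OC` gives 190 nM

Compound 3 sits within the scatter of compound 1, and both have lower numbers than compound 2, by more than the scatter. Compound 4 `COc1cccc(-c2cn(-c3ccccc3)cc2C(=O)c2cc(OC)c(OC)c(OC)c2)c1` is not yet measured. It differs from compound 3 by having 3-methoxyphenyl in place of 2-bromophenyl on an aromatic carbon and nothing else. For the measured compounds named here, the one measured step that bears on this is a 3.3-fold higher number from compound 1 to compound 2 (0.52 log units; beyond the scatter), where methoxy replaced chloro on an aromatic carbon elsewhere in the molecule. That modest step at another place is only a loose guide. A similarly modest rise is expected, and the estimated step is a 1.8-fold higher number from compound 3 to compound 4 (0.27 log units; within the scatter) in this assay. For compound 4 the estimated value is 350 nM within an expected range from 110 nM to 1100 nM.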

Compound 4, half-maximal inhibitory concentration: 180 nM
The estimate for compound 4 lay 1.9-fold (0.29 log units) above the measured number; the measured number falls inside the stated range.
By their numbers in this assay, from the lowest: compounds 1, 4 and 3 (each within the scatter of the next); then compound 2.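

In this assay, putting 3-methoxyphenyl in place of 2-bromophenyl on this aromatic carbon gives a 1.1-fold lower number from compound 3 to compound 4 (0.02 log units; within the scatter) and so leaves the two numbers indistinguishable, even though the rings carry different groups at different ring positions. Methoxy in place of chloro elsewhere in the molecule gave a 3.3-fold higher number from compound 1 to compound 2 (0.52 log units; beyond the scatter) and that larger step does not recur here. Nothing measured here explains this result. On these data alone, whether this ring could carry an amine or a carboxylic acid with as little effect on the number remains open.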